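Methylating a phenol in a kinase-like pyrazole series

The source may hold more compounds than are shown below. What is called first, only, known or untested is meant among the compounds shown, and "the series" means these compounds.

Measured compounds:
- compound 1, `O=C(Nc1cccc(-n2cc(-c3ccncc3)c(-c3cc(O)cc(Cl)c3)n2)c1)Nc1ccc(Cl)c(Cl)c1`, -47.4%
- compound 2, `COc1cc(Cl)cc(-c2nn(-c3cccc(NC(=O)Nc4ccc(Cl)c(Cl)c4)c3)cc2-c2ccncc2)c1`, 4.11%
- compound 3, `O=C(Nc1cccc(-n2cc(-c3ccncc3)c(-c3cc(O)cc(Cl)c3)n2)c1)c1cc(C(F)(F)F)cc(C(F)(F)F)c1`, 15.2%

All three compounds were tested in a functional assay on OVCAR-3 cells (Homo sapiens) for inhibition, read by sulforhodamine B assay, with a stated time of 48 h, tested at 10 uM; on this read-out higher numbers stand for a weaker effect at the one concentration tested and lower numbers for a stronger effect. Compound 1 gives -47.4%, the lowest number of the three. Compound 2 differs from compound 1 by a single change, (methyl in place of hydrogen on an oxygen on an aromatic ring), and this change moves the read-out by a number 51.5 percentage points higher from compound 1 to compound 2 (beyond the scatter). Compound 3 carries the same hydroxy-bearing ring as compound 1 but a different remainder; the difference between the two cores is not broken down here. In this assay compound 3 gives 15.2%, the highest number of the three.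

Compound 4, `COc1cc(Cl)cc(-c2nn(-c3cccc(NC(=O)c4cc(C(F)(F)F)cc(C(F)(F)F)c4)c3)cc2-c2ccncc2)c1`, has not yet been measured. Within the data shown here, it differs from compound 3 by methyl in place of hydrogen on an oxygen on an aromatic ring, which is the same change, at the same place, as the one from compound 1 to compound 2. Because that earlier change produced a number 51.5 percentage points higher from compound 1 to compound 2 (beyond the scatter), a step of similar direction is expected here, although it is seen only once and on a different core, so its size on the core of compound 3 is uncertain. The step expected from compound 3 to compound 4 is a number 29.8 percentage points higher from compound 3 to compound 4 (beyond the scatter). For compound 4 the estimated value in this assay is therefore 45%, with a range from 5% to 85%.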

Compound 4, a percentage reported as activity, at one concentration (the size of the read-out at that concentration, not a potency): 25.5%
The estimate for compound 4 lay 19.5 percentage points above the measured number, and the stated range covers the measured number.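

In this assay, changing hydroxy to methoxy on the second core gives a number 10.3 percentage points higher from compound 3 to compound 4 (beyond the scatter), so the number moves in the same direction as it did on the first core. The size of the step does not carry over, however, and a step measured on one core would have been a poor guide to its exact size on the other: the same change on two cores in this assay, a number 51.5 percentage points higher (beyond the scatter) from compound 1 to compound 2 and a number 10.3 percentage points higher (beyond the scatter) from compound 3 to compound 4, 41.2 percentage points apart, beyond the scatter of two such steps Two cores are too few to make a rule for the whole series, and these two pairs do not show which part of the remainder of the molecule sets the size of the step, or why the step differs at all.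

The compounds shown leave open how this position responds to anything other than hydroxy and methoxy, for example an ethoxy group or a longer chain on the oxygen, or an amine in place of the hydroxy. They also leave open whether the same change would keep its direction on a third core, such as one joined through a sulfonamide instead of the urea of compound 1 or the amide of compound 3.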